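Swapping the fluorophenyl amide of compound 2 for a methylcyclohexyl

The source may report more compounds than this note shows. Statements on the series, on what has been measured and on what is new or still open speak of the compounds shown alone.

Of the compounds shown here, three sharing one core have been measured in a functional assay on Raji cells (Homo sapiens) for antiproliferative activity, read by CCK-8 assay, with a stated time of 72 h, tested at 40 uM; on this read-out higher numbers stand for more inhibition at the one concentration tested (going by the name of the read-out) and lower numbers for less inhibition. Compound 1 `CCOC(=O)c1sc(-c2cccc(NC(=O)c3ccccc3)c2)nc1Nc1ccc(N2CCN(C)CC2)cc1` gives 42%. Compound 2 `CCOC(=O)c1sc(-c2cccc(NC(=O)c3ccccc3F)c2)nc1Nc1ccc(N2CCN(C)CC2)cc1` gives 89.8%, and compound 3 `CCOC(=O)c1sc(-c2cccc(NC(=O)c3ccc(F)c(Cl)c3)c2)nc1Nc1ccc(N2CCN(C)CC2)cc1` gives 20.7%. Compound 2 therefore stands highest of the three: the step of a number 47.8 percentage points higher from compound 1 to compound 2 (beyond the scatter) lifted the number clearly, and the step of a number 69.1 percentage points lower from compound 2 to compound 3 (beyond the scatter) dropped it clearly, while a number 21.3 percentage points lower from compound 1 to compound 3 (beyond the scatter) was a modest fall. All three differ only in the group attached to the carbonyl carbon of the amide.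

Compound 4 `CCOC(=O)c1sc(-c2cccc(NC(=O)[C@H]3CC[C@H](C)CC3)c2)nc1Nc1ccc(N2CCN(C)CC2)cc1` has not yet been measured in this assay. The change from compound 2 is 4-methylcyclohexyl in place of 2-fluorophenyl on a carbonyl carbon. Going by the values given here, the measured steps show that this part of the molecule moves the read-out a great deal in either direction, but every measured step kept an aromatic ring at this carbonyl; none exchanged it for a non-aromatic ring, so no step bears directly on compound 4. Because compound 2 sits at the top with 89.8%, a drop is more likely than a rise, though the size is very uncertain. For compound 4 the expected step is a number 44.8 percentage points lower from compound 2 to compound 4 (beyond the scatter), and the expected value is 45%, within a range from 10% to 85%.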

Compound 4, a percentage reported as inhibition, at one concentration (the size of the read-out at that concentration, not a potency): 26.1%
Compound 4: the middle estimate sits 18.9 percentage points above what was measured, within the range that was stated.
By their numbers in this assay, from the lowest: compounds 3 and 4 (each within the scatter of the next); then compound 1; then compound 2.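

In this assay, the 4-methylcyclohexyl is the only non-aromatic ring at this carbonyl carbon among the compounds shown, and putting it in place of the 2-fluorophenyl gives a large fall: a number 63.7 percentage points lower from compound 2 to compound 4 (beyond the scatter). It also gives a modest fall against the plain phenyl, a number 15.9 percentage points lower from compound 1 to compound 4 (beyond the scatter), whereas the gap to the 3-chloro-4-fluorophenyl does not separate the two compounds: a number 5.4 percentage points higher from compound 3 to compound 4 (within the scatter). A six-membered ring with the same count of heavy atoms therefore does not by itself bring back the high number of compound 2, and no accompanying measurement points to what lies behind these numbers.

The compounds shown leave open whether the high number of compound 2 depends on the aromatic ring, on the fluoro group, or on both together, since only one compound carries that combination. From the compounds shown here alone, it also remains open how a plain cyclohexyl without the methyl, the other stereoisomer of the 4-methylcyclohexyl, or a longer open chain such as hexyl would behave on this carbonyl carbon.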